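A few compounds are considered here, and "the series" means these few. Any claim that something is new, unique, unknown or untested is made for them only; others in the source may bear on it.

Both compounds of this set were tested in a functional assay with Cavia porcellus as the target; a lower number here means a stronger inhibitor, a higher number a weaker inhibitor. Compound 1 `COc1ccc([N+](C)(C)Cc2ccccc2)cc1` gives > 3000 nM in this assay, a limit and not a number. Compound 2 `C=CC[N+](C)(C)Cc1cccc(O)c1` likewise gives > 3000 nM in this assay, again a limit rather than a number. Compound 2 thus stands at a limit, as does every value shown, since (the limit of > 3000 nM in this assay, at which 2 of the 2 values shown sit). Compound 3 `C[N+](C)(C)Cc1cccc(O)c1` differs from compound 2 by hydrogen in place of vinyl on a saturated chain carbon bound to an amine nitrogen, which cut one bond further out reads allyl to methyl. Among the compounds with values here, no measured step covers this change, so its size in this assay is open; a change this small is expected to stay within the usual scatter, with no clear direction. Compound 3 is therefore expected to remain near the same limit, an estimated step that the limit leaves unreadable from compound 2 to compound 3. For compound 3 the estimate is 6000 nM, within a range from 2000 nM to 30000 nM.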

Compound 3, half-maximal inhibitory concentration: > 3000 nM
Compound 3 ended at the assay's limit; the forecaster's own chance of this, stated with the estimate: 75%; the middle value does not contradict the limit.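

Within the data shown here, compound 2 and compound 3 each give only a limit and not a number in this assay and no step between them can be read. The compounds shown leave open how strongly each one inhibits, and whether changing allyl to methyl alters that strength at all.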